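The source may report more compounds than this note shows. Statements on the series, on what has been measured and on what is new or still open speak of the compounds shown alone.

Of the compounds shown here, three sharing one core have been tested in a functional assay on DU-145 cells (Homo sapiens) for cytotoxicity, read by resazurin assay, with a stated time of 72 h; a lower number here means a stronger inhibitor, a higher number a weaker inhibitor. Compound 1 `Clc1nss/c1=N\c1ccc(OCc2ccccc2)cc1` gives 45000 nM, compound 2 `Cc1cc(OC(F)(F)F)ccc1/N=c1\ssnc1Cl` gives 18000 nM, and compound 3 `FC(F)(F)Oc1ccc(/N=c2\ssnc2Cl)cc1Br` gives 52000 nM. On these numbers compound 3 sits at the high end, yet its gap to compound 1 falls within the usual scatter of such measurements, while compound 2 lies beyond that scatter, giving a clearly lower number. Compound 4 `Clc1nss/c1=N\c1cccc(Br)c1` differs from compound 3 in one place: hydrogen in place of trifluoromethoxy on an aromatic carbon. Within the data shown here, no measured pair isolates this change, so the expectation rests on the weak potency of all three neighbours. In this assay the step from compound 3 to compound 4 is expected to be a 1.2-fold higher number from compound 3 to compound 4 (0.06 log units; within the scatter), not beyond the scatter. Compound 4 is therefore estimated at 60000 nM, within 20000 nM to 180000 nM.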

Compound 4, half-maximal inhibitory concentration: 27000 nM
Estimate against measurement, compound 4: 2.2-fold (0.35 log units) above; the range from low to high includes it.
By their numbers in this assay, from the lowest: compounds 2, 4, 1 and 3 (each within the scatter of the next, the first and the last beyond it).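

In this assay, hydrogen in place of trifluoromethoxy gives a 1.9-fold lower number from compound 3 to compound 4 (0.28 log units; within the scatter). Among these compounds, no earlier pair isolated a single place on this ring, and this one shows that, with the bromo group kept, losing all five heavy atoms of the trifluoromethoxy group does not shift the number beyond the scatter. No measured evidence bears on the reason for this result. From the compounds shown here alone, whether an amine, a carboxylic acid or a longer chain at this aromatic carbon would shift the number beyond the scatter stays open. Also open, going by these compounds, is whether the same change would behave alike without the bromo group.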